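The source may report more compounds than this note shows. Statements on the series, on what has been measured and on what is new or still open speak of the compounds shown alone.

Compound 1 `O=C(NCCCCc1ccccc1)n1cccn1` and compound 2 `Cc1cnn(C(=O)NCCCCc2ccccc2)c1` share one core. In an assay on isolated protein for inhibition of Fatty-acid amide hydrolase 1 (Rattus norvegicus), with a stated time of 3 h (on this read-out lower numbers stand for stronger inhibition and higher numbers for weaker inhibition), compound 1 gives 290 nM, and compound 2 gives 550 nM. The change between them, (methyl in place of hydrogen on an aromatic carbon), made the step of a 1.9-fold higher number from compound 1 to compound 2 (0.28 log units; within the scatter). Compound 3 `O=C(CCCCCc1ccccc1)n1cccn1` has another core; how the two cores differ is not broken down here. In this assay compound 3 gives > 5000 nM, which is a limit of the assay and not a number. Compound 4 `Cc1cnn(C(=O)CCCCCc2ccccc2)c1` arises from compound 3 by the same change, (methyl in place of hydrogen on an aromatic carbon). The step from compound 3 to compound 4 is expected to be a step that the limit leaves unreadable from compound 3 to compound 4, resting on the step of a 1.9-fold higher number from compound 1 to compound 2 (0.28 log units; within the scatter). Compound 4 is therefore expected to give about 9000 nM, most likely again only a limit, because compound 3 already sits at the limit of > 5000 nM in this assay, at which 1 of the 3 values shown sits.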

Compound 4, inhibition constant: > 5000 nM
Compound 4 ended at the assay's limit; the forecaster's own chance of this, stated with the estimate: 80%; the middle value lies beyond the limit too.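

Going by these compounds alone, compound 3 and compound 4 both end at a limit and not at a number, so no step between them can be read: the limit of > 5000 nM in this assay, at which 2 of the 4 values shown sit. The compounds shown leave open whether methyl in place of hydrogen changes inhibition at all on the core of compound 3 in this assay.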